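The source may report more compounds than this note shows. Statements on the series, on what has been measured and on what is new or still open speak of the compounds shown alone.

Compound 1, `N#CC1=C(N)Oc2c(N)cc3nc4ccccc4nc3c2C12C(=O)N(Cc1cnnn1-c1ccc(Cl)cc1)c1ccccc12`, in a functional assay on A549 cells (Homo sapiens) for antiproliferative activity, read by MTT assay, with a stated time of 48 h (on this read-out lower numbers stand for stronger inhibition and higher numbers for weaker inhibition), gives a value that is a limit of the assay: > 50000 nM.
Compound 2, `COc1ccc(-n2nncc2CN2C(=O)C3(C(C#N)=C(N)Oc4c(N)cc5nc6ccccc6nc5c43)c3ccccc32)cc1`, in this assay gives likewise a limit: > 50000 nM.
Compound 3, `Cc1ccc(-n2nncc2CN2C(=O)C3(C(C#N)=C(N)Oc4c(N)cc5nc6ccccc6nc5c43)c3ccccc32)cc1C`, in this assay gives again a limit: > 50000 nM.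

Compound 3 therefore stands where every measured compound here stands, at the limit of > 50000 nM in this assay, at which 3 of the 3 values shown sit, with no number behind it. The three compounds share one core and differ only in the aryl group attached to the nitrogen of the five-membered aromatic ring with three nitrogens. The three changes among them, a step that the two limits leave unreadable from compound 1 to compound 2, a step that the two limits leave unreadable from compound 1 to compound 3 and a step that the two limits leave unreadable from compound 2 to compound 3, are all unreadable because both of their ends sit at the limit of > 50000 nM in this assay, at which 3 of the 3 values shown sit.

Compound 4, `CCc1cccc(CC)c1-n1nncc1CN1C(=O)C2(C(C#N)=C(N)Oc3c(N)cc4nc5ccccc5nc4c32)c2ccccc21`, differs from compound 3 by 2,6-diethylphenyl in place of 3,4-dimethylphenyl on an aromatic nitrogen. Among the measured compounds shown here, it is the same kind of exchange, an aryl group for another aryl group on that nitrogen, and none of the measured exchanges of this kind has given a readable size in this assay. The expected step that the limit leaves unreadable from compound 3 to compound 4 is therefore none that could be read out beyond the limit. Compound 4 is expected to give about 60000 nM, in a range from 20000 nM to 200000 nM, and most likely to be reported again only as a limit.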

Compound 4, half-maximal inhibitory concentration: > 50000 nM
Compound 4 was reported as a limit; the forecaster's own chance of this, stated with the estimate: 85%; the middle value lies beyond the limit too.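

Compound 4 gives > 50000 nM in this assay as a limit of the assay, not a number. Among the compounds shown here, no step among compound 1, compound 2, compound 3 and compound 4 can be read, because all four end at the same limit: (the limit of > 50000 nM in this assay, at which 4 of the 4 values shown sit). The compounds shown leave open whether any aryl group on that nitrogen gives a measurable value in this assay at all.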